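The source may report more compounds than this note shows. Statements on the series, on what has been measured and on what is new or still open speak of the compounds shown alone.

Series notes on the shared core. In an assay on HEK293 cells for displacement of a labelled ligand from NPC1-like intracellular cholesterol transporter 1 (Homo sapiens) (on this read-out lower numbers stand for stronger inhibition and higher numbers for weaker inhibition), compound 1 `CCC1CCCN(C(=O)CN2CN(c3ccccc3)C3(CCN(C(=O)c4ccc(C5CCCCC5)cc4)CC3)C2=O)C1` gives 2600 nM. Compound 2 `O=C(CN1CN(c2ccccc2)C2(CCN(C(=O)c3ccc(C4CCCCC4)cc3)CC2)C1=O)NCCCCO` gives 10300 nM in this assay, and compound 3 `CCC1CCCN(C(=O)CN2CN(c3ccccc3)C3(CCN(C(=O)c4ccc(C(C)(C)C)cc4)CC3)C2=O)C1` gives 3900 nM in this assay. Compound 1 and compound 3 lie within the scatter of each other: a 1.5-fold higher number from compound 1 to compound 3 (0.18 log units; within the scatter). The change from compound 1 to compound 2 is (4-hydroxybutyl)amino in place of 3-ethylpiperidin-1-yl on a carbonyl carbon, and it made a 4.0-fold higher number from compound 1 to compound 2 (0.60 log units; beyond the scatter).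

Compound 4 `CC(C)(C)c1ccc(C(=O)N2CCC3(CC2)C(=O)N(CC(=O)NCCCCO)CN3c2ccccc2)cc1` has not yet been measured in this assay. It differs from compound 3 by (4-hydroxybutyl)amino in place of 3-ethylpiperidin-1-yl on a carbonyl carbon. This is the same change as the one from compound 1 to compound 2, and it occurs twice among the compounds shown; the place is the same in both instances. The two cores differ by tert-butyl in place of cyclohexyl on an aromatic carbon.

Resting on the single earlier instance, a 4.0-fold higher number from compound 1 to compound 2 (0.60 log units; beyond the scatter), the step from compound 3 to compound 4 in this assay is expected to be a 3.8-fold higher number from compound 3 to compound 4 (0.59 log units; beyond the scatter). Compound 4 is therefore estimated at about 15000 nM in this assay, with an expected range from 6000 nM to 40000 nM.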

Compound 4, half-maximal inhibitory concentration: 19200 nM
Beside the measured number, compound 4's estimate is 1.3-fold (0.11 log units) below it; the range from low to high includes it.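

In this assay, (4-hydroxybutyl)amino in place of 3-ethylpiperidin-1-yl on a carbonyl carbon makes a 4.9-fold higher number from compound 3 to compound 4 (0.69 log units; beyond the scatter), and the size of this step carries over between the two cores: the same change on two cores in this assay, a 4.0-fold higher number (0.60 log units; beyond the scatter) from compound 1 to compound 2 and a 4.9-fold higher number (0.69 log units; beyond the scatter) from compound 3 to compound 4, 1.2-fold (0.09 log units) apart, within the scatter of two such steps

The other change, tert-butyl in place of cyclohexyl on an aromatic carbon, makes a 1.9-fold higher number from compound 2 to compound 4 (0.27 log units; within the scatter) and also reads the same with either group on the carbonyl carbon: the same change on two cores in this assay, a 1.5-fold higher number (0.18 log units; within the scatter) from compound 1 to compound 3 and a 1.9-fold higher number (0.27 log units; within the scatter) from compound 2 to compound 4, 1.2-fold (0.09 log units) apart, within the scatter of two such steps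

This shows the two changes acting independently within these four compounds only; with a single pair on each core, it does not show that the step would transfer to other cores in the series.

Still open, as far as these compounds go, is which part of the exchange goes with the step: the ring, the ethyl group or the hydroxyl. A plain butylamino group, an unsubstituted piperidin-1-yl or a longer hydroxyalkyl chain on the same carbonyl carbon would separate these, and a methoxy group in place of tert-butyl or cyclohexyl would test the step on a further core.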